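The source may report more compounds than this note shows. Statements on the series, on what has been measured and on what is new or still open speak of the compounds shown alone.

Measured in an ADME assay on HCT-116 cells (Homo sapiens) for cytotoxicity, read by CellTiter-Glo, with a stated time of 72 h; a lower number here means a stronger inhibitor, a higher number a weaker inhibitor:
- compound 1 `CCCC(=O)N(Cc1ccccc1)C1CCN(S(=O)(=O)c2c(C)cc(C)cc2C)CC1` gives > 5000 nM (a limit)
- compound 2 `Cc1noc(C)c1S(=O)(=O)N1CCC(N2CCC(C)CC2)CC1` gives > 10000 nM (a limit)

Compound 2 stands at > 10000 nM in this assay, which is a limit and not a number. Compound 3 `CC1CCN(C2CCN(S(=O)(=O)c3ccc(C#N)cc3)CC2)CC1` differs from compound 2 by one change on the sulfonyl sulfur, 4-cyanophenyl in place of 3,5-dimethyl-1,2-oxazol-4-yl on a sulfonyl sulfur. For the measured compounds named here, no measured step bears on this change. The expected change, a step that the limit leaves unreadable from compound 2 to compound 3, is none beyond the scatter, in neither direction, and a further limit is likely. For compound 3 the estimate is 12000 nM, with an expected range from 4000 nM to 30000 nM in this read-out.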

Compound 3, half-maximal inhibitory concentration: > 5000 nM
Compound 3: only a limit was reported; the forecaster's own chance of this, stated with the estimate: 75%; the middle value is on the limit's open side.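

Compound 2 and compound 3 are both reported only as limits in this assay, so no step can be read between them. The compounds shown leave open whether 4-cyanophenyl and 3,5-dimethyl-1,2-oxazol-4-yl on the sulfonyl sulfur differ at all in this assay.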